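Capping the phenol of compound 2: what to expect

This account rests on a few compounds, and the source may have more. Where it says the series, first, only, none or still open, it means among the compounds named here.

compound 1, `COc1ccc2c(=O)c(/C=C/C(=O)NCc3ccccc3)coc2c1`: > 100000 nM
compound 2, `Cc1ccccc1NC(=O)/C=C/c1coc2cc(O)ccc2c1=O`: 9320 nM

Both compounds were tested in a functional assay (QGY7701 cells, Homo sapiens) for inhibition, read by MTT assay, with a stated time of 48 h; on this read-out lower numbers stand for stronger inhibition and higher numbers for weaker inhibition. Compound 2 gives 9320 nM, the only real number shown. The other value is a limit of the assay, (the limit of > 100000 nM in this assay, at which 1 of the 2 values shown sits), and that is where compound 1 sits. Compound 1 and compound 2 differ in more than one place, so their values can only be placed side by side, not read as a single step.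

Compound 3 `COc1ccc2c(=O)c(/C=C/C(=O)Nc3ccccc3C)coc2c1` differs from compound 2 by methyl in place of hydrogen on an oxygen on an aromatic ring. Among the compounds with values here, no measured pair spans exactly this change. Compound 1, which also carries a methoxy group, sits at the limit, so the expected step from compound 2 to compound 3 in this assay is a 3.2-fold higher number from compound 2 to compound 3 (0.51 log units; beyond the scatter), toward weaker inhibition and beyond the scatter. Compound 3 is therefore expected to give 30000 nM, between 8000 nM and 100000 nM.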

Compound 3, half-maximal inhibitory concentration: 22500 nM
Estimate against measurement, compound 3: 1.3-fold (0.12 log units) above; low and high end bracket the measured number.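

In this assay, hydroxy to methoxy on this oxygen now has a direct reading: a 2.4-fold higher number from compound 2 to compound 3 (0.38 log units; beyond the scatter). Capping the phenol therefore weakens inhibition without removing it, and compound 3 still gives a real number. With the methoxy group held in place, 2-methylphenyl in place of benzyl on the amide-type nitrogen gives an at least 4.4-fold lower number from compound 1 to compound 3 (0.64 log units; beyond the scatter), so the methoxy group alone does not put a compound at the edge of the assay. The value of compound 1 is a limit of the assay, not a number: the limit of > 100000 nM in this assay, at which 1 of the 3 values shown sits.

As far as these compounds go, how an ethoxy group or a longer chain on this oxygen would read stays open, as does an amine in place of the oxygen. Also open, from the compounds shown here alone, is whether hydroxy to methoxy keeps its size with benzyl on the amide-type nitrogen.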